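Swapping an aryl group for a benzyl on a thiosemicarbazide

The source may hold more compounds than are shown below. What is called first, only, known or untested is meant among the compounds shown, and "the series" means these compounds.

Among the compounds with values here, compound 1 `Fc1cccc(NC(=S)N/N=C/c2ccc3ccccc3n2)c1` is the only one of three measured compounds to give an actual number in a functional assay on SGC-7901 cells (Homo sapiens) for antiproliferative activity, read by sulforhodamine B assay, with a stated time of 72 h; a lower number here means a stronger inhibitor, a higher number a weaker inhibitor: compound 1 reaches 79900 nM, a weak result. Compound 2 `NC(=S)N/N=C/c1nc2ccccc2s1` gives only a limit of the assay, > 100000 nM, in this assay. Compound 3 `NC(=S)N/N=C/c1cnc2ccccc2n1` likewise stays at the limit of > 100000 nM in this assay. So compound 1 stands alone with a measured value, while the other two sit at the limit of > 100000 nM in this assay, at which 2 of the 3 values shown sit. Compound 4 `S=C(NCc1ccccc1)N/N=C/c1ccc2ccccc2n1` keeps the core of compound 1 and changes one group: benzyl in place of 3-fluorophenyl on an amide-type nitrogen. Within the data shown here, no measured pair shows a step of this kind, so the expected change in this assay is small, within the scatter, with no clear direction. Compound 4 is therefore estimated at 60000 nM, between 15000 nM and 150000 nM. The expected step is a 1.3-fold lower number from compound 1 to compound 4 (0.12 log units; within the scatter).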

Compound 4, half-maximal inhibitory concentration: 53700 nM
Compound 4: middle estimate off by 1.1-fold (0.05 log units), on the high side; the measured number falls inside the stated range.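

In this assay, benzyl in place of 3-fluorophenyl on the amide-type nitrogen gives a 1.5-fold lower number from compound 1 to compound 4 (0.17 log units; within the scatter), so the two groups cannot be told apart at this position. The fluorine is therefore not needed to keep this weak activity, and the ring need not sit directly on the nitrogen. Compound 2 and compound 3 remain at a limit of the assay, not a number: the limit of > 100000 nM in this assay, at which 2 of the 4 values shown sit.

A single step cannot show how much this position tolerates. On these data alone, whether a longer chain or a carboxylic acid on this nitrogen would shift the number beyond the scatter remains open.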